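The source may report more compounds than this note shows. Statements on the series, on what has been measured and on what is new or still open speak of the compounds shown alone.

Going by the values given here, compound 2 `Oc1n[nH]c(CN[C@H](COCc2cc(C(F)(F)F)cc(C(F)(F)F)c2)c2ccccc2)n1` gives 2.4 nM in an assay on CHO cells for displacement of a labelled ligand from Substance-P receptor (Homo sapiens) (on this read-out higher numbers stand for weaker inhibition and lower numbers for stronger inhibition), and stands second highest of the three numbers so far; compound 1 `CN(Cc1nc[nH]n1)[C@H](COCc1cc(C(F)(F)F)cc(C(F)(F)F)c1)c1ccccc1` gives 1.4 nM and compound 3 `Cn1nnnc1CN[C@H](COCc1cc(C(F)(F)F)cc(C(F)(F)F)c1)c1ccccc1` gives 10 nM. Compound 4 `CCN(Cc1n[nH]c(O)n1)[C@H](COCc1cc(C(F)(F)F)cc(C(F)(F)F)c1)c1ccccc1` carries ethyl((5-hydroxy-1H-1,2,4-triazol-3-yl)methyl)amino in place of ((3-hydroxy-1H-1,2,4-triazol-5-yl)methyl)amino on a saturated chain carbon bound to an aromatic carbon and a saturated chain carbon. Among the compounds with values here, the only measured step that touches the amine nitrogen is a 1.7-fold higher number from compound 1 to compound 2 (0.23 log units; within the scatter), in which a methyl on that nitrogen and a hydroxy on the ring were exchanged together. The steps of a 7.1-fold higher number from compound 1 to compound 3 (0.85 log units; beyond the scatter) and a 4.2-fold higher number from compound 2 to compound 3 (0.62 log units; beyond the scatter) concern the ring itself and bear little on an ethyl at the nitrogen. Within the data shown here, no measured step isolates alkylation of the amine, so in this assay a step of about a 1.0-fold higher number from compound 2 to compound 4 (0.02 log units; within the scatter) is expected, not beyond the scatter. Compound 4 is therefore estimated at 2.5 nM, range 0.9 nM to 7 nM.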

Compound 4, half-maximal inhibitory concentration: 0.8 nM
Beside the measured number, compound 4's estimate is 3.1-fold (0.49 log units) above it, and the stated range ends above it.
By their numbers in this assay, from the lowest: compounds 4, 1 and 2 (each within the scatter of the next, the first and the last beyond it); then compound 3.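

In this assay, an ethyl on the amino group of the hydroxytriazole series does not cost binding and goes with stronger inhibition than the unsubstituted amino group (a 3.0-fold lower number from compound 2 to compound 4 (0.48 log units; beyond the scatter)). Against the methylated triazole compound there is no separation (a 1.8-fold lower number from compound 1 to compound 4 (0.24 log units; within the scatter)), so ethyl and methyl amines cannot be told apart here. The gap to the methyltetrazole compound is large (a 13-fold lower number from compound 3 to compound 4 (1.10 log units; beyond the scatter)). Open, from the compounds shown here alone, is whether a longer chain such as propyl or a benzyl group on that amino group keeps this level. No measured evidence accounts for the gain.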